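Methoxy to dimethylamino: a step expected within scatter

The compounds below may be only part of what the source reports. "The series", "measured", "known", "first", "only" and "open" are said of these compounds alone.

Of the compounds shown here, two have been measured in a physicochemical assay for acid dissociation. Compound 1 `COc1ccc(F)cc1CNCCCNc1ccnc2cc(C3CCCCC3)ccc12` gives 9.47, and compound 2 `COc1cccc(Oc2ccc3c(NCCCNCc4cc(F)ccc4OC)ccnc3c2)c1` gives 9.28. Among the measured compounds shown here, the only recorded step, a number 0.19 log units lower from compound 1 to compound 2 (within the scatter), puts 3-methoxyphenoxy in place of cyclohexyl on an aromatic carbon. Compound 2 thus sits alongside compound 1, the two numbers within the scatter of each other. Compound 3 `COc1ccc(F)cc1CNCCCNc1ccnc2cc(Oc3cccc(N(C)C)c3)ccc12` differs from compound 2 in a single place: dimethylamino in place of methoxy on an aromatic carbon. For the measured compounds named here, no measured pair bears on this particular exchange; the one step on record, which stayed within the scatter, is the only guide, and it gives no reason to anticipate a step beyond the scatter for the change to compound 3. In this assay compound 3 is expected to give about 9.3, with a range from 8.9 to 9.7. The step is estimated as a number 0.02 log units higher from compound 2 to compound 3 (within the scatter), within the scatter.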

Compound 3, acid dissociation constant: 9.28
Compound 3: middle estimate off by 0.02 log units, on the high side; measured number inside the range.
By their numbers in this assay, from the lowest: compounds 2, 3 and 1 (each within the scatter of the next).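

In this assay, dimethylamino in place of methoxy on an aromatic carbon, meta to a large group, gives no change at the digits printed from compound 2 to compound 3 (within the scatter), so two different groups at this position now read alike. The second new step, 3-(dimethylamino)phenoxy in place of cyclohexyl, gives a number 0.19 log units lower from compound 1 to compound 3 (within the scatter), which leaves compound 3 within the scatter of compound 1, as compound 2 already was. All three compounds thus lie within the scatter of one another, and nothing available explains these readings.

As far as these compounds go, whether a carboxylic acid or a primary amine on this aromatic carbon would produce a step beyond the scatter remains open. So does the outcome of a longer chain in place of the one shared by all three compounds.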